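The compounds below may be only part of what the source reports. "The series", "measured", "known", "first", "only" and "open" are said of these compounds alone.

Three compounds of this series have been examined in an ADME assay on Vero cells (Chlorocebus sabaeus) for cytotoxicity, read by MTT assay, with a stated time of 72 h; a lower number here means that less compound is tolerated, a higher number that more compound is tolerated. Compound 1 `COC(=O)c1cc(-c2cccc(NC(=O)c3ccc(/C=C/C(=O)c4cccnc4)cc3)c2)on1` carries no result there; its entry reads "not determined" (no result reported). For compound 2 `COC(=O)c1cc(-c2cccc(NC(=O)c3ccc(/C=C/C(=O)c4ccc(OC)cc4)cc3)c2)on1` the assay gives only a limit, > 10 ug/mL. For compound 3 `CCCOc1ccc(C(=O)/C=C/c2ccc(C(=O)O)cc2)cc1` the assay likewise gives only a limit, < 10 ug/mL. Compound 2 therefore stands at the tolerated end of what is shown, and no step between measured compounds can be counted. Compound 4 `COC(=O)c1cc(-c2cccc(NC(=O)c3ccc(/C=C/C(=O)c4ccc(Br)cc4)cc3)c2)on1` differs from compound 2 by bromo in place of methoxy on an aromatic carbon. Among the compounds with values here, with no measured step to lean on, the expected step from compound 2 to compound 4 in this assay is a number no higher from compound 2 to compound 4 (the limit leaves the size open), not beyond the usual scatter in either direction. Compound 4 is thus expected to give 10 ug/mL, between 4 ug/mL and 25 ug/mL.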

Compound 4, half-maximal cytotoxic concentration: > 20 ug/mL
Compound 4 ended at the assay's limit; the forecaster's own chance of this, stated with the estimate: 60%; at least 2.0-fold (0.30 log units) between middle value and limit.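

Compound 2 and compound 4 each stand only as a limit in this assay, and the step between them cannot be read. The compounds shown leave open whether bromo in place of methoxy changes the tolerated concentration at all.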